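Butoxy to phenethyloxy on the chloro-bearing core

This account rests on a few compounds, and the source may have more. Where it says the series, first, only, none or still open, it means among the compounds named here.

Compound 2 `CCCCOc1ccc2c(Cl)ccnc2c1` is the point of departure. In a functional assay on RKO cells (Homo sapiens) for cytotoxicity, read by MTT assay, with a stated time of 48 h (a higher number here means a weaker inhibitor, a lower number a stronger inhibitor), compound 2 gives 3050 nM, and its nearest neighbour is compound 1 `CC(C)COc1ccc2c(Cl)ccnc2c1`, which in this assay gives 2680 nM; the step of a 1.1-fold higher number from compound 1 to compound 2 (0.06 log units; within the scatter) is within the scatter, so the two stand level. For the measured compounds named here, compound 3 `CN(C)CCNc1ccnc2cc(OCc3ccccc3)ccc12` gives 2350 nM in this assay, a number also within the scatter of compound 2, though compound 3 differs from compound 2 at two places and no single step connects them.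

Compound 4 `Clc1ccnc2cc(OCCc3ccccc3)ccc12` carries the change (phenyl in place of ethyl on a saturated chain carbon, two bonds along the chain from an oxygen on an aromatic ring). Going by the values given here, the only measured single step, the one from compound 1 to compound 2, concerns a different branch of the chain and was flat; the series has no step that exchanges a chain carbon for a phenyl at this place. With nothing pointing either way, the expectation for compound 4 in this assay is a step of a 1.1-fold lower number from compound 2 to compound 4 (0.04 log units; within the scatter) that stays within the scatter, neither stronger nor weaker beyond it. The estimate for compound 4 is 2800 nM, with a range from 1200 nM to 6500 nM.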

Compound 4, half-maximal inhibitory concentration: 2560 nM
For compound 4 the middle estimate is 1.1-fold (0.04 log units) above the measured one; the range from low to high includes it.
By their numbers in this assay, from the lowest: compounds 3, 4, 1 and 2 (each within the scatter of the next).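

In this assay, a 1.2-fold lower number from compound 2 to compound 4 (0.08 log units; within the scatter) stays within the scatter, so phenyl in place of ethyl, on a saturated chain carbon two bonds along the chain from an oxygen on an aromatic ring, leaves the number level. The earlier step, a 1.1-fold higher number from compound 1 to compound 2 (0.06 log units; within the scatter), exchanged only one saturated chain for another; this step shows that a six-membered aromatic ring can enter the chain on the oxygen with no change beyond the scatter. No measurement at hand bears on the reason for this flat result.

As far as these compounds go, whether a longer chain before the phenyl, or a phenyl carrying an amine or a carboxylic acid, would shift the number remains open. Compound 3 differs from compound 4 at more than one place, so it gives no separate reading of this change.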